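The source may report more compounds than this note shows. Statements on the series, on what has been measured and on what is new or still open speak of the compounds shown alone.

In an ADME assay on Vero cells (Chlorocebus sabaeus) for cytotoxicity, with a stated time of 3 days (a higher number here means a weaker inhibitor, a lower number a stronger inhibitor), compound 3 `CCOC(=O)Nc1cc(NC(=O)c2ccc(OC)cc2)c2[nH]c(-c3ccc(C(=O)OC)cc3)nc2c1` gives only a limit, > 200 ug/mL. Compound 1 `CCOC(=O)Nc1cc(NC(=O)c2ccccc2)c2[nH]c(-c3ccc(Br)cc3)nc2c1` likewise stops at a limit, > 200 ug/mL. Compound 2 `CCOC(=O)Nc1cc(NC(=O)C2CCCCC2)c2[nH]c(-c3ccc(C(=O)OC)cc3)nc2c1` also reaches only a limit, > 200 ug/mL. For the measured compounds named here, every value shown thus sits at the limit of > 200 ug/mL in this assay, at which 3 of the 3 values shown sit, and the single measured change, a step that the two limits leave unreadable from compound 2 to compound 3, cannot be read for size or direction. Compound 4 `CCOC(=O)Nc1cc(NC(=O)c2ccccc2)c2[nH]c(-c3ccc(C(=O)OC)cc3)nc2c1` differs from compound 3 by hydrogen in place of methoxy on an aromatic carbon. Going by the values given here, no measured step gives a readable size for this change, since the one step that touches a comparable position is itself unreadable between two limits. Compound 4 is therefore expected to show a step of a number no higher from compound 3 to compound 4 (the limit leaves the size open) in this assay, with an estimated value of 200 ug/mL, within a range from 100 ug/mL to 400 ug/mL.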

Compound 4, half-maximal inhibitory concentration: 650 ug/mL
The estimate for compound 4 lay 3.3-fold (0.51 log units) below the measured number; the whole stated range lies below it.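

The steps from compound 1, compound 2 and compound 3 to compound 4 cannot be read in this assay, because those three compounds give only limits: the limit of > 200 ug/mL in this assay, at which 3 of the 4 values shown sit. The compounds shown leave open the size and direction of each of these changes.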